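A few compounds are considered here, and "the series" means these few. Any claim that something is new, unique, unknown or untested is made for them only; others in the source may bear on it.

Measured so far in a functional assay on Jurkat cells (Homo sapiens) for cytotoxicity, read by luminescence and CellTiter-Glo, with a stated time of 3 days; a lower number here means a stronger inhibitor, a higher number a weaker inhibitor:

Compound 1 `O=C(Nc1ccc(Br)c(Cl)c1)c1cc(F)ccc1O` gives 860 nM.
Compound 2 `N#Cc1ccc(NC(=O)c2ccc3cccnc3c2O)c(Cl)c1` gives 550 nM.
Compound 3 `N#Cc1ccc(NC(=O)c2cc(Cl)ccc2O)c(Cl)c1` gives 620 nM.

The three numbers sit close together. Compound 2 stands at the low end of them, but its gap to compound 3 and its gap to compound 1 both fall inside the usual scatter, so no order among the three can be read from these values, and compound 2 cannot be called the stronger inhibitor on this evidence.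

Compound 4 `N#Cc1ccc(NC(=O)c2ccc3cccnc3c2O)c(C#N)c1` has not yet been measured. It differs from compound 2 in one place: cyano in place of chloro on an aromatic carbon. The amide, the phenol and the ring system of compound 2 are kept; only the substituent on the aniline ring is exchanged.

For the measured compounds named here, no pair of measured compounds differs by this exchange alone, so there is no measured step to lean on. Compound 3 carries the same chloro and cyano pair on its aniline ring as compound 2 and lands close to it, but that says nothing about the swap itself. The working expectation is a step that stays within the scatter, with no clear direction. Compound 4 is expected at 700 nM, between 300 nM and 1600 nM, which means an estimated step of a 1.3-fold higher number from compound 2 to compound 4 (0.10 log units; within the scatter) in this assay.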

Compound 4, half-maximal inhibitory concentration: 270 nM
Estimate against measurement, compound 4: 2.6-fold (0.41 log units) above; measured number outside the range, below it.
By their numbers in this assay, from the lowest: compound 4; then compounds 2, 3 and 1 (each within the scatter of the next).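

In this assay, for the compounds shown here, the aromatic carbon ortho to a large group and meta to a cyano group is the first place where a single exchange gives a step beyond the scatter. Cyano in place of chloro gives a 2.0-fold lower number from compound 2 to compound 4 (0.31 log units; beyond the scatter), a modest step that leaves the amide, the phenol and the rest of compound 2 unchanged. The entering cyano brings a triple bond and a hydrogen-bond acceptor that chloro does not have, but no measurement available here ties the step to either feature or to anything else.

On these data alone, this step rests on a single pair, so it remains open whether cyano in place of chloro gives a similar step on the core of compound 3, which carries a different acid-side ring. As far as these compounds go, it also remains open how this position responds to groups outside the chloro and cyano pair, such as methoxy, trifluoromethyl, an amine or a longer chain, and therefore whether the step is specific to the cyano group.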